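A few compounds are considered here, and "the series" means these few. Any claim that something is new, unique, unknown or untested is made for them only; others in the source may bear on it.

Working notes on the series, step from compound 1 to compound 4.

Compound 1 `CC1(C)S[C@@H]2/C(=C\C(=O)c3ccc4ccccc4c3)C(=O)N2[C@H]1C(=O)OC(c1ccccc1)c1ccccc1` is the aryl ketone bearing naphthalen-2-yl. In a functional assay on A-375 cells (Homo sapiens) for cytotoxicity, read by MTT assay, with a stated time of 48 h (a lower number here means a stronger inhibitor, a higher number a weaker inhibitor), compound 1 gives 36500 nM. Among the three numbers measured so far, compound 1 stands second highest. Its nearest neighbour is compound 3 `CC1(C)S[C@@H]2/C(=C\C(=O)c3ccccc3)C(=O)N2[C@H]1C(=O)OC(c1ccccc1)c1ccccc1`, with 22800 nM in this assay; the step of a 1.6-fold lower number from compound 1 to compound 3 (0.20 log units; within the scatter) is within the scatter. Furthest away is compound 2 `CC(=O)/C=C1/C(=O)N2[C@@H]1SC(C)(C)[C@@H]2C(=O)OC(c1ccccc1)c1ccccc1`, the methyl ketone, with 63000 nM in this assay; the step of a 1.7-fold higher number from compound 1 to compound 2 (0.24 log units; within the scatter) is also within the scatter. Within the data shown here, the only step in the set that goes beyond the scatter is a 2.8-fold lower number from compound 2 to compound 3 (0.44 log units; beyond the scatter), a modest one, so the series as measured is nearly flat.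

Compound 4 `COC(=O)/C=C1/C(=O)N2[C@@H]1SC(C)(C)[C@@H]2C(=O)OC(c1ccccc1)c1ccccc1` has not yet been measured. It differs from compound 1 by methoxy in place of naphthalen-2-yl on a carbonyl carbon; cut one bond further out, the change reads (naphthalen-2-yl)carbonyl to methoxycarbonyl. The step that bears on it most is a 1.7-fold higher number from compound 1 to compound 2 (0.24 log units; within the scatter), where naphthalen-2-yl also gives way to a small group on the carbonyl carbon, and that step stayed within the scatter; a 1.6-fold lower number from compound 1 to compound 3 (0.20 log units; within the scatter) likewise stayed within the scatter. No step beyond the scatter is therefore expected in this assay, though if anything a slightly higher number, as the measured steps away from an aryl ketone have run.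

For compound 4 the estimate in this assay is 55000 nM, with a range of 20000 nM to 150000 nM, corresponding to an expected step of a 1.5-fold higher number from compound 1 to compound 4 (0.18 log units; within the scatter).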

Compound 4, half-maximal inhibitory concentration: 24600 nM
Compound 4: middle estimate off by 2.2-fold (0.35 log units), on the high side; the measured number falls inside the stated range.
By their numbers in this assay, from the lowest: compounds 3, 4, 1 and 2 (each within the scatter of the next, the first and the last beyond it).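

In this assay, the step of a 1.5-fold lower number from compound 1 to compound 4 (0.17 log units; within the scatter) shows that methoxy can replace naphthalen-2-yl on this carbonyl carbon without a change beyond the scatter, and the step of a 1.1-fold higher number from compound 3 to compound 4 (0.03 log units; within the scatter) shows the same for methoxy in place of phenyl, so the two aryl ketones and the ringless methoxycarbonyl compound cannot be told apart here. The step of a 2.6-fold lower number from compound 2 to compound 4 (0.41 log units; beyond the scatter) separates two ringless groups, which rules out the loss of an aromatic ring as a sufficient description of the earlier gap between compound 2 and compound 3; among these four compounds, only compound 2 lies beyond the scatter of any other, and even it remains within the scatter of compound 1. No measured evidence is available to explain why methoxy and methyl part in this way.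

From the compounds shown here alone, it remains open whether the close grouping of compound 3, compound 4 and compound 1 would extend to an amide formed from a simple amine, a free carboxylic acid or a longer alkyl chain on the ester oxygen at this carbonyl carbon. Going by these compounds, it is equally open whether a second methyl ketone analogue, such as an ethyl ketone, would sit with compound 2 or with the other three.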